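Moving from a propyl chain to a carboxylated chain on a shared core

This account rests on a few compounds, and the source may have more. Where it says the series, first, only, none or still open, it means among the compounds named here.

Of the compounds shown here, two built on the same core have so far been measured in a functional assay on P388 cells (Mus musculus) for cytotoxicity; a higher number here means a weaker inhibitor, a lower number a stronger inhibitor. Compound 1 `Cc1csc2ncnc(NCc3ccc(Cl)cc3)c12` gives 170 nM in this assay. Compound 2 `CCCNc1ncnc2scc(C)c12` gives 5500 nM in this assay, the highest of the two numbers, and its gap to compound 1 lies well beyond the usual scatter of the measurement. Compound 3 `Cc1csc2ncnc(NCCC(=O)O)c12` has not yet been measured. It differs from compound 2 in one place: carboxy in place of methyl on a saturated chain carbon, two bonds along the chain from a nitrogen on an aromatic ring. Within the data shown here, no pair of measured compounds shows a step of this kind, so nothing measured here tells how far the number moves when the end of the chain changes in this way. Only an expectation can be given. The change is expected to leave compound 3 at or somewhat beyond the weaker end of the two numbers seen, and the step from compound 2 to compound 3 is estimated as a 2.7-fold higher number from compound 2 to compound 3 (0.44 log units; beyond the scatter). The value of compound 3 in this assay is therefore estimated at 15000 nM, with a likely range from 4000 nM to 60000 nM.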

Compound 3, half-maximal inhibitory concentration: 12000 nM
Beside the measured number, compound 3's estimate is 1.3-fold (0.10 log units) above it; measured number inside the range.
By their numbers in this assay, from the lowest: compound 1; then compound 2; then compound 3.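

In this assay, carboxy in place of methyl on a saturated chain carbon, two bonds along the chain from a nitrogen on an aromatic ring, brings a 2.2-fold higher number from compound 2 to compound 3 (0.34 log units; beyond the scatter) and thus a modest change. Among these compounds, this is the first step measured at this position, and it shows that the number responds to what sits at the end of the chain. Among the compounds shown here, the propyl to 2-carboxyethyl change moves the number towards weaker inhibition, though the move is small compared with the full range of estimates that the earlier compounds allowed. Nothing available explains the direction or the size of this step.

The compounds shown leave open whether the weaker result is particular to the carboxylic acid or would also appear with another group at the end of the same chain, such as an amine, a primary amide or a methyl ester. They also leave open how the number would move with a longer chain ending in a carboxylic acid, or with a hydroxyl group in place of the carboxy.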